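The source may report more compounds than this note shows. Statements on the series, on what has been measured and on what is new or still open speak of the compounds shown alone.

Going by the values given here, compound 1 `CC[C@H](C)C(N)c1cc(C(F)(F)F)ccc1N1CCN(C(=O)CCc2ccc(Cl)cc2Cl)CC1` carries the lowest number of the three compounds measured so far: in an assay on HEK293 cells for displacement of a labelled ligand from Melanocortin receptor 4 (Homo sapiens) (a higher number here means a weaker inhibitor, a lower number a stronger inhibitor), compound 1 gives 75 nM. Of the other two, compound 2 `CC(C)C[C@H](N)c1cc(C(F)(F)F)ccc1N1CCN(C(=O)CCc2cccs2)CC1` gives 4600 nM in this assay, and compound 3 `CC(C)C[C@H](N)c1cc(C(F)(F)F)ccc1N1CCN(C(=O)CCc2csc3ccccc23)CC1` gives 2300 nM. Among the compounds with values here, both of these differ from compound 1 in more than one place, so no single step links either of them to compound 1. Within the data shown here, the one step that is available, a 2.0-fold lower number from compound 2 to compound 3 (0.30 log units; within the scatter), concerns the exchange of thiophen-2-yl for 1-benzothiophen-3-yl and says nothing about the 1-amino-2-methylbutyl group that is altered here.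

Compound 4 `CCC(C)[C@H](NC(C)=O)c1cc(C(F)(F)F)ccc1N1CCN(C(=O)CCc2ccc(Cl)cc2Cl)CC1` differs from compound 1 in one place: 1-acetamido-2-methylbutyl in place of 1-amino-2-methylbutyl on an aromatic carbon. Among the measured compounds shown here, no measured pair covers this change, so the expectation rests on compound 1 at 75 nM alone and carries a wide range. For compound 4 the expected step is an 8.0-fold higher number from compound 1 to compound 4 (0.90 log units; beyond the scatter), toward a higher number. Compound 4 is therefore estimated at 600 nM, with a range from 100 nM to 4000 nM.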

Compound 4, inhibition constant: 360 nM
For compound 4 the middle estimate is 1.7-fold (0.22 log units) above the measured one; measured number inside the range.
By their numbers in this assay, from the lowest: compound 1; then compound 4; then compounds 3 and 2 (each within the scatter of the next).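

Changing 1-amino-2-methylbutyl to 1-acetamido-2-methylbutyl on this aromatic carbon gives a 4.8-fold higher number from compound 1 to compound 4 (0.68 log units; beyond the scatter) in this assay, so this position responds to the change, though the step is modest in size. Compound 4 still gives 360 nM, which shows that the nitrogen of this side chain can carry an acetyl group without binding being lost altogether. Nothing measured on these compounds accounts for the size of the step.

As far as these compounds go, whether the step follows from the acetyl group in particular remains open, since a single methyl on the nitrogen, a benzoyl group or a methanesulfonyl group would each test a different replacement at the same place. Also open, from the compounds shown here alone, is whether the same change gives a similar step when the thiophen-2-yl or 1-benzothiophen-3-yl group replaces the dichlorophenyl group.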